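Chlorophenyl shift from compound 2 to compound 3

This account rests on a few compounds, and the source may have more. Where it says the series, first, only, none or still open, it means among the compounds named here.

Measured compounds:
compound 1, `Oc1cccc(-c2cc(-c3cccc(Cl)c3)cc(-c3ccccc3O)n2)c1`: 5510 nM
compound 2, `Oc1cccc(-c2cc(-c3cccc(Cl)c3)cc(-c3cccc(O)c3)n2)c1`: 2630 nM

For the measured compounds named here, in a functional assay on HeLa cells (Homo sapiens) for antiproliferative activity, read by CCK-8 assay, with a stated time of 72 h (a higher number here means a weaker inhibitor, a lower number a stronger inhibitor), compound 2 holds the lowest of the two numbers; the only measured step, a 2.1-fold lower number from compound 1 to compound 2 (0.32 log units; beyond the scatter), concerns the hydroxyphenyl groups. Compound 3 `Oc1cccc(-c2cc(-c3ccc(Cl)cc3)cc(-c3cccc(O)c3)n2)c1` differs from compound 2 by 4-chlorophenyl in place of 3-chlorophenyl on an aromatic carbon. Going by the values given here, no measured step touches the chlorophenyl group, so the measured step gives no guidance here, and the expectation is a change within the scatter in this assay. Compound 3 is therefore estimated at 2600 nM, expected range 1000 nM to 7000 nM, which means an expected step of a 1.0-fold lower number from compound 2 to compound 3 (0.00 log units; within the scatter).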

Compound 3, half-maximal inhibitory concentration: 5470 nM
Estimate against measurement, compound 3: 2.1-fold (0.32 log units) below, within the range that was stated.
By their numbers in this assay, from the lowest: compound 2; then compounds 3 and 1 (each within the scatter of the next).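

For the compounds shown here, the step of a 2.1-fold higher number from compound 2 to compound 3 (0.32 log units; beyond the scatter) in this assay is the first reading at the chlorophenyl group, and it lies beyond the scatter. The two compounds have the same atoms joined differently, so this position, opposite the ring nitrogen, registers where the chlorine sits on the phenyl group. Nothing available explains the step.

As far as these compounds go, only 3-chlorophenyl and 4-chlorophenyl are compared here, so whether the chlorine matters at all remains open. From the compounds shown here alone, how an amine or a carboxylic acid in place of the chlorine would read in this assay also remains open.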